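The compounds below may be only part of what the source reports. "The series", "measured", "known", "first", "only" and "open" are said of these compounds alone.

Going by the values given here, in an ADME assay on K562 cells (Homo sapiens) for cytotoxicity, with a stated time of 72 h (a lower number here means a stronger inhibitor, a higher number a weaker inhibitor), compound 2 `COc1cccc(CNc2ncnc3c2ncn3C2CCCCO2)c1` gives 61000 nM, the only true number measured so far. Compound 1 `Oc1ccc(CNc2ncnc3c2ncn3C2CCCCO2)cc1` gives > 100000 nM, which is a limit of the assay and not a number. Among the compounds with values here, the single measured step, an at least 1.6-fold lower number from compound 1 to compound 2 (0.21 log units; that floor lies within the scatter), replaces the hydroxy-bearing aromatic group of compound 1 with the methoxy-bearing group of compound 2. Compound 3 `COc1cc(CNc2ncnc3c2ncn3C2CCCCO2)ccc1O` combines features of both, keeping the methoxy group and gaining a hydroxy: hydroxy in place of hydrogen on an aromatic carbon. The hydroxy sits on an aromatic carbon, ortho to a methoxy group and para to a large group.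

Within the data shown here, no measured step isolates this change, so the evidence is thin. Compound 1, the hydroxy-bearing compound, gives only a limit, and the estimate has to allow for (the limit of > 100000 nM in this assay, at which 1 of the 2 values shown sits). In this assay, a small move toward a higher number is therefore expected, probably not beyond the scatter, and the expected step is a 1.3-fold higher number from compound 2 to compound 3 (0.12 log units; within the scatter). Compound 3 is estimated at 80000 nM, with an expected range of 35000 nM to 180000 nM.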

Compound 3, half-maximal inhibitory concentration: > 100000 nM
Compound 3: a limit, no number; the forecaster's own chance of this, stated with the estimate: 45%; middle value at least 1.2-fold (0.09 log units) away from the limit.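

In this assay compound 3 gives > 100000 nM, which is a limit of the assay and not a number. Placing a hydroxy on this aromatic carbon, ortho to a methoxy group and para to a large group, gives an at least 1.6-fold higher number from compound 2 to compound 3 (0.21 log units; that floor lies within the scatter), so the change brings no sign of a stronger inhibitor, although the smallest step the data allow stays within the scatter. Both compounds that carry a hydroxy on the aromatic ring, compound 1 and compound 3, now end in limits, and compound 2, which has none, is the only one with a true number, but the step between compound 1 and compound 3 cannot be read, and the true size of the hydroxy step stays unknown because of how many values are limits: the limit of > 100000 nM in this assay, at which 2 of the 3 values shown sit.

From the compounds shown here alone, how far compound 3 really lies from compound 2 remains open. Also open, going by these compounds, is whether an amine, a fluorine or a carboxylic acid on the same aromatic carbon would move the number of compound 2 in either direction, and by more than the scatter.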